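The source may hold more compounds than are shown below. What is called first, only, known or untested is meant among the compounds shown, and "the series" means these compounds.

Measured so far:
compound 1 `CN(C)c1ccc(/C=C2\CCC/C(=C\c3ccccc3[N+](=O)[O-])C2=O)cc1`: in a physicochemical assay for lipophilicity (on this read-out lower numbers stand for lower lipophilicity and higher numbers for higher lipophilicity), compound 1 gives 4.8
compound 2 `COc1cc(/C=C2\CCC/C(=C\c3ccccc3[N+](=O)[O-])C2=O)cc(OC)c1OC`: in this assay compound 2 gives 4.33
compound 3 `CN(C)c1ccc(/C=C2\CCC/C(=C\c3cccc([N+](=O)[O-])c3)C2=O)cc1`: in this assay compound 3 gives 5

Compound 1 and compound 3 are built on one core, compound 2 on another; the difference between the two cores is not broken down here. The change from compound 1 to compound 3 is 3-nitrophenyl in place of 2-nitrophenyl on a double-bonded chain carbon bound to a double-bonded ring carbon, and in this assay it gave a number 0.20 log units higher from compound 1 to compound 3 (within the scatter). Compound 2 stands lowest of the three numbers, with compound 1 beyond the scatter above it and compound 3 further above still.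

Compound 4 `COc1cc(/C=C2\CCC/C(=C\c3cccc([N+](=O)[O-])c3)C2=O)cc(OC)c1OC` has not been measured. Going by the values given here, it differs from compound 2 by 3-nitrophenyl in place of 2-nitrophenyl on a double-bonded chain carbon bound to a double-bonded ring carbon, the same change in the same place as that from compound 1 to compound 3, which is the only measured instance of it. Because that instance gave a number 0.20 log units higher from compound 1 to compound 3 (within the scatter), the step from compound 2 to compound 4 is expected to be of like size, a number 0.20 log units higher from compound 2 to compound 4 (within the scatter). Compound 4 is accordingly estimated at 4.53 in this assay. The expected range for compound 4 runs from 4.15 to 4.9, resting on a single precedent.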

Compound 4, partition coefficient: 4.53
For compound 4 middle estimate and measured number coincide at the digits printed; measured number inside the range.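

Carried to the core of compound 2, 3-nitrophenyl in place of 2-nitrophenyl gives in this assay a number 0.20 log units higher from compound 2 to compound 4 (within the scatter) and this matches in size a number 0.20 log units higher from compound 1 to compound 3 (within the scatter) so the step transfers between these two cores without any visible dependence on the core. Going by these compounds alone, both steps lie within the scatter, so the pairs do not establish that 3-nitrophenyl and 2-nitrophenyl differ on this read-out, and the agreement shows only that no core dependence appears, not that a shared shift exists. Nothing available bears on the reason for this result.

The compounds shown leave open how the read-out responds when a different kind of group, such as a carboxylic acid or an amine, stands on a double-bonded chain carbon bound to a double-bonded ring carbon. On these data alone, whether the match between the two steps would extend to a third core also remains open.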